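This account rests on a few compounds, and the source may have more. Where it says the series, first, only, none or still open, it means among the compounds named here.

Compound 1 `COc1cc(C(=O)O)ccc1Cc1cn(C2CCCC2)c2ccc(NC(=O)OC3CCCC3)cc12` gives 7.67 in an assay on isolated protein (Cavia porcellus) with cysteinyl leukotriene receptor (Homo sapiens) as the target; a lower number here means a less potent compound, a higher number a more potent compound, by a factor of ten per unit of this negative logarithm. Among the three compounds measured, none gives a number below it, and the two others stay within the usual scatter of it: compound 3 `COc1cc(C(=O)O)ccc1Cn1ccc2ccc(NC(=O)OC3CCCC3)cc21`, which gives 7.8 in this assay, lies nearest, and compound 2 `COc1cc(C(=O)NS(=O)(=O)c2ccccc2)ccc1Cc1cn(C2CCCC2)c2ccc(NC(=O)OC3CCCC3)cc12`, which gives 7.84 in this assay, lies furthest from it. Going by the values given here, the only step measured in one place is a number 0.17 log units higher from compound 1 to compound 2 (within the scatter), and it concerns the carbonyl carbon, not the aromatic nitrogen. Compound 4 `CCCn1cc(Cc2ccc(C(=O)O)cc2OC)c2cc(NC(=O)OC3CCCC3)ccc21` differs from compound 1 in a different spot: propyl in place of cyclopentyl on an aromatic nitrogen. Among the compounds with values here, no measured step touches the group on that aromatic nitrogen, so none bears directly on this change, and the one step that is known is itself within the scatter. The change from compound 1 to compound 4 is therefore expected to bring no shift beyond the scatter, an estimated a number 0.07 log units lower from compound 1 to compound 4 (within the scatter). Compound 4 is thus expected to give about 7.6 in this assay, within the range 7.1 to 8.1.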

Compound 4, negative logarithm of the antagonist equilibrium constant: 7.72
Compound 4: middle estimate off by 0.12 log units, on the low side; low and high end bracket the measured number.
By their numbers in this assay, from the lowest: compounds 1, 4, 3 and 2 (each within the scatter of the next).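

Going by these compounds alone, the change from cyclopentyl to propyl on the aromatic nitrogen gives a number 0.05 log units higher from compound 1 to compound 4 (within the scatter) in this assay, and this is the first measured step at that group. For this pair, an open propyl chain takes the place of a five-membered non-aromatic ring of carbon only without a shift beyond the scatter. The ring on that nitrogen is therefore not needed to keep the number in this assay, at least when the rest of compound 1 stays unchanged.

The compounds shown leave open whether a longer chain such as hexyl, a smaller group such as methyl, or a chain ending in an amine or a carboxylic acid on that nitrogen would keep the number as well. They also leave open whether propyl would give the same result with (phenylsulfonyl)amino on the carbonyl carbon. No measured evidence bears on this result.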